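Replacing the Hydroxyphenyl Ester in a Short-Lived Diester

The source may hold more compounds than are shown below. What is called first, only, known or untested is meant among the compounds shown, and "the series" means these compounds.

Of the compounds shown here, three sharing one core have been measured in an ADME assay on a cell-free system (plasma, Homo sapiens) for metabolic stability, with Plasma (Rattus norvegicus) as the target, read by HPLC, at pH 7.4; on this read-out higher numbers stand for a longer-lived compound and lower numbers for a shorter-lived compound. Compound 1 `CC(=O)Oc1ccccc1C(=O)O[C@H]1CO[C@H]2[C@@H]1OC[C@H]2OC(=O)c1ccccc1O` gives 0.0825 h, the highest of the three numbers. Compound 2 `CC(=O)Oc1ccccc1C(=O)O[C@H]1CO[C@H]2[C@@H]1OC[C@H]2OC(=O)c1cccc(O)c1` gives 0.0183 h, and compound 3 `COc1ccc(C(=O)O[C@@H]2CO[C@H]3[C@@H]2OC[C@@H]3OC(=O)c2ccccc2OC(C)=O)cc1` gives 0.0525 h. The steps from compound 1 show a 4.5-fold lower number from compound 1 to compound 2 (0.65 log units; beyond the scatter) and a 1.6-fold lower number from compound 1 to compound 3 (0.20 log units; within the scatter); between the other two, a 2.9-fold higher number from compound 2 to compound 3 (0.46 log units; beyond the scatter).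

Compound 4 `CC(=O)Oc1ccccc1C(=O)O[C@H]1CO[C@H]2[C@@H]1OC[C@H]2OC(=O)c1cc(C)nc(Cl)c1` has not yet been measured. It differs from compound 1 in one place: 2-chloro-6-methylpyridin-4-yl in place of 2-hydroxyphenyl on a carbonyl carbon. Within the data shown here, no measured step makes this exact exchange, so only the two earlier replacements of the 2-hydroxyphenyl group offer guidance; both lowered the number, one beyond the scatter and one within it. On that basis the estimate for compound 4 in this assay is a small decrease, a 1.7-fold lower number from compound 1 to compound 4 (0.22 log units; within the scatter), with little confidence in the direction. The expected value for compound 4 is 0.05 h, within a range from 0.02 h to 0.12 h.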

Compound 4, half-life: 0.0193 h
Compound 4: middle estimate off by 2.6-fold (0.41 log units), on the high side, and the stated range ends above it.
By their numbers in this assay, from the lowest: compounds 2 and 4 (each within the scatter of the next); then compounds 3 and 1 (each within the scatter of the next).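

Exchanging 2-hydroxyphenyl for 2-chloro-6-methylpyridin-4-yl on this carbonyl carbon gives a 4.3-fold lower number from compound 1 to compound 4 (0.63 log units; beyond the scatter) in this assay, so a replacement here can cost as much as the 3-hydroxyphenyl group did, and not only stay within the scatter as the 4-methoxyphenyl group did. The two replacements without a hydroxyl group also part clearly, with a 2.7-fold lower number from compound 3 to compound 4 (0.43 log units; beyond the scatter), so losing the hydrogen-bond donor does not fix the number at one level. Against the 3-hydroxyphenyl group the new ring shows a 1.1-fold higher number from compound 2 to compound 4 (0.02 log units; within the scatter), so two very different rings cannot be told apart here, and the donor count alone does not sort these compounds: compound 2 has a donor, compound 4 has none.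

Nothing available explains why these groups rank as they do. On these data alone, whether an amine or a carboxylic acid on this ring would lengthen the half-life remains open.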